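This account rests on a few compounds, and the source may have more. Where it says the series, first, only, none or still open, it means among the compounds named here.

Series notes. Compound 1 `CC(=O)Nc1nc(-c2cccc(NS(=O)(=O)c3ccc(C#CCO)cc3)c2)cs1` and compound 2 `C#Cc1cccc(S(=O)(=O)Nc2cccc(-c3csc(NC(C)=O)n3)c2)c1` share the core of compound 1 and differ only in one substituent. In a functional assay on A-375 cells (Homo sapiens) for antiproliferative activity, read by trypan blue exclusion, with a stated time of 48 h, tested at 10 uM (a higher number here means a weaker effect of the compound at the concentration tested, a lower number a stronger effect), compound 1 gives 48.8%, and in this assay compound 2 gives 18.6%. Within the data shown here, compound 1 thus holds the highest of the two numbers measured so far, and its gap to compound 2 lies beyond the usual scatter; no single-point step between these two has been worked out, so the pair is read from its two values alone.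

Compound 3 `CCCCCCc1ccc(S(=O)(=O)Nc2cccc(-c3csc(NC(C)=O)n3)c2)cc1` has not yet been measured in this assay. It differs from compound 1 as follows: hexyl in place of 3-hydroxyprop-1-yn-1-yl on an aromatic carbon. Among the measured compounds shown here, no measured step of this kind exists in the set, and the two values at hand give no guide for hexyl. A moderate fall in the number is expected, as a number 13.8 percentage points lower from compound 1 to compound 3 (beyond the scatter), though the direction is not secure. Compound 3 is expected to give about 35% in this assay, estimated to lie between 12% and 65%.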

Compound 3, a percentage reported as activity, at one concentration (the size of the read-out at that concentration, not a potency): <= 1%
Compound 3 gave a limit, no number; the forecaster's own chance of this, stated with the estimate: 0%; middle value at least 34 percentage points away from the limit.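

Hexyl in place of 3-hydroxyprop-1-yn-1-yl on an aromatic carbon, para to a large group, gives a number at least 47.8 percentage points lower from compound 1 to compound 3 (beyond the scatter) in this assay, so the group at this position can decide the size of the read-out. Compound 3 stands at a limit of the assay and not at a number, so the step has a minimum size only: the limit of <= 1% in this assay, at which 1 of the 3 values shown sits. The change swaps a chain with a triple bond, 1 hydrogen-bond donor and 1 hydrogen-bond acceptor for a chain of 6 carbons with 0 of either, and the stronger effect comes with that swap.

This one step cannot separate the roles of the hydroxyl, the triple bond and the chain length. It also leaves open whether a butyl chain, or a hexyl chain ending in an amine or a carboxylic acid, would keep the read-out near this limit.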